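Bromine to Chlorine on Two Related Cores

The compounds below may be only part of what the source reports. "The series", "measured", "known", "first", "only" and "open" are said of these compounds alone.

Compound 1 `Cc1nc(C)c(-c2nn(-c3ccc(F)cc3)cc2/C=C/C(=O)c2cc(Br)ccc2O)s1` is measured in an ADME assay on HeLa cells (Homo sapiens) for inhibition, read by MTT assay (a higher number here means a weaker inhibitor of growth, a lower number a stronger inhibitor of growth), and gives 4.88 ug/mL. Compound 2 `Cc1nc(C)c(-c2nn(-c3ccc(F)cc3)cc2/C=C/C(=O)c2cc(Cl)ccc2O)s1` differs from it by chloro in place of bromo on an aromatic carbon. In this assay compound 2 reaches only a limit, > 250 ug/mL. The change produced an at least 51-fold higher number from compound 1 to compound 2 (1.70 log units; beyond the scatter). Compound 3 `Cc1nc(C)c(-c2nn(-c3ccc(F)cc3)cc2C2CC(c3cc(Br)ccc3O)=NN2)s1` rests on a different core; how the two cores differ is not broken down here. In this assay compound 3 gives 21.6 ug/mL. Compound 4 `Cc1nc(C)c(-c2nn(-c3ccc(F)cc3)cc2C2CC(c3cc(Cl)ccc3O)=NN2)s1` differs from compound 3 by chloro in place of bromo on an aromatic carbon, the same change as between compound 1 and compound 2. Because the limit of > 250 ug/mL in this assay, at which 1 of the 3 values shown sits, caps what the assay can report, a step of the first size may again end at that limit. For compound 4 the expected step in this assay is a 9.3-fold higher number from compound 3 to compound 4 (0.97 log units; beyond the scatter). That expectation rests on an at least 51-fold higher number from compound 1 to compound 2 (1.70 log units; beyond the scatter). Compound 4 is estimated at 200 ug/mL, between 50 ug/mL and 250 ug/mL.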

Compound 4, concentration for 50% growth inhibition: > 250 ug/mL
Compound 4: a limit, no number; the forecaster's own chance of this, stated with the estimate: 65%; middle value at least 1.2-fold (0.09 log units) away from the limit.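

Compound 4 gives > 250 ug/mL in this assay as a limit and not a number. Chloro in place of bromo gives an at least 11-fold higher number from compound 3 to compound 4 (1.06 log units; beyond the scatter), so the change moves the number the same way on both cores: the same change on two cores in this assay, an at least 51-fold higher number (1.70 log units; beyond the scatter) from compound 1 to compound 2 and an at least 11-fold higher number (1.06 log units; beyond the scatter) from compound 3 to compound 4; the limit leaves it open whether they differ. The direction therefore carries across these two cores, but the size of the step cannot be compared, because both chloro compounds stop at the limit: the limit of > 250 ug/mL in this assay, at which 2 of the 4 values shown sit.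

The compounds shown leave open how a fluoro, a methoxy or an amine in the place of the halogen would read on either core. They also leave open whether the change behaves the same way on any further core.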